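Working notes: pyridin-3-yl in place of phenyl

The source may hold more compounds than are shown below. What is called first, only, known or untested is meant among the compounds shown, and "the series" means these compounds.

Measured so far:
- Compound 1 `Oc1ccc(-c2cc(-c3ccccc3)cc(-c3ccc(O)cc3)n2)cc1` gives 5700 nM
- Compound 2 `Oc1cccc(-c2cc(-c3ccccc3)nc(-c3ccccc3)c2)c1` gives 13500 nM

In a functional assay on HL-60 cells (Homo sapiens) for cytotoxicity, read by ELISA, with a stated time of 2 days (on this read-out lower numbers stand for stronger inhibition and higher numbers for weaker inhibition), compound 1 gives 5700 nM and compound 2 holds the higher of the two numbers with 13500 nM. The gap between these two compounds lies beyond the scatter. Compound 3 `Oc1cccc(-c2cc(-c3ccccc3)nc(-c3cccnc3)c2)c1` carries pyridin-3-yl in place of phenyl on an aromatic carbon, next to the ring nitrogen. Among the measured compounds shown here, no measured pair shows this change on its own. In this assay a small move toward a lower number is expected, not beyond the scatter. The expected step (a 1.4-fold lower number from compound 2 to compound 3 (0.13 log units; within the scatter)) is modest. Compound 3 is expected at 10000 nM (estimated range 4000 nM to 25000 nM).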

Compound 3, half-maximal inhibitory concentration: 12600 nM
Compound 3: the middle estimate sits 1.3-fold (0.10 log units) below what was measured; the measured number falls inside the stated range.
By their numbers in this assay, from the lowest: compound 1; then compounds 3 and 2 (each within the scatter of the next).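

Pyridin-3-yl in place of phenyl on this aromatic carbon, next to the ring nitrogen, gives a 1.1-fold lower number from compound 2 to compound 3 (0.03 log units; within the scatter) in this assay. This position therefore accepts a ring nitrogen and one hydrogen-bond acceptor with the read-out staying within the scatter. No supporting data bear on this result.

The compounds shown leave open whether pyridin-4-yl or pyridin-2-yl in the same place would give a step beyond the scatter. They also leave open what an amine or a carboxylic acid on this ring would do.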